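A few compounds are considered here, and "the series" means these few. Any claim that something is new, unique, unknown or untested is made for them only; others in the source may bear on it.

Among the compounds with values here, compound 2 `N#CC1=C(N)Oc2c(N)cc3nc4ccccc4nc3c2C12C(=O)N(Cc1cnnn1-c1cc(Cl)ccc1Cl)c1ccccc12` is the only compound here with a definite number: in a functional assay on MCF7 cells (Homo sapiens) for antiproliferative activity, read by MTT assay, with a stated time of 48 h (a higher number here means a weaker inhibitor, a lower number a stronger inhibitor), compound 2 gives 33200 nM. Compound 1 `Cc1ccc(-n2nncc2CN2C(=O)C3(C(C#N)=C(N)Oc4c(N)cc5nc6ccccc6nc5c43)c3ccccc32)cc1C` reaches only a limit of the assay, (the limit of > 50000 nM in this assay, at which 1 of the 2 values shown sits); in this assay compound 1 gives > 50000 nM. Within the data shown here, the one measured step, an at least 1.5-fold lower number from compound 1 to compound 2 (0.17 log units; that floor lies within the scatter), also swaps the group on the aromatic nitrogen. Compound 3 `N#CC1=C(N)Oc2c(N)cc3nc4ccccc4nc3c2C12C(=O)N(Cc1cnnn1-c1ccc(Cl)cc1[N+](=O)[O-])c1ccccc12` differs from compound 2 by 4-chloro-2-nitrophenyl in place of 2,5-dichlorophenyl on an aromatic nitrogen. Since that measured step has a floor within the scatter, no change beyond the scatter is expected: the estimated step is a 1.0-fold lower number from compound 2 to compound 3 (0.00 log units; within the scatter), and compound 3 is expected to give 33000 nM, between 15000 nM and 75000 nM.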

Compound 3, half-maximal inhibitory concentration: > 50000 nM
Compound 3 was reported as a limit (the forecaster's own chance of this, stated with the estimate: 30%); middle value at least 1.5-fold (0.18 log units) from the limit.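

Compound 3 shows that a nitro-bearing ring on this aromatic nitrogen also ends at the assay's limit, as the 3,4-dimethylphenyl ring of compound 1 did: the limit of > 50000 nM in this assay, at which 2 of the 3 values shown sit. Swapping 2,5-dichlorophenyl for 4-chloro-2-nitrophenyl gives an at least 1.5-fold higher number from compound 2 to compound 3 (0.17 log units; that floor lies within the scatter), and the true size may be larger, since only a floor is known. The step between the two limits cannot be read.

Still open, going by these compounds, is whether any group at this position gives much stronger inhibition. A phenyl ring carrying an amine or a carboxylic acid, or a longer alkyl chain in place of the ring, would test this.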